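The source may hold more compounds than are shown below. What is called first, only, known or untested is meant among the compounds shown, and "the series" means these compounds.

Working notes on the series. In an ADME assay on the whole organism (plasma, Rattus norvegicus, strain Sprague-Dawley), at a dose of 10 mg/kg by the oral route (on this read-out higher numbers stand for higher exposure at the dose given and lower numbers for lower exposure), compound 1 (`CCCCNc1nc(N)nc2ccccc12`) gives 56 ng.h/mL and compound 2 (`CCCCNc1nc(N)nc2cccc(C(=O)N(C)Cc3ccccc3)c12`) gives 37 ng.h/mL. Going by the values given here, these two values lie within the scatter of each other, so compound 2 stands level with compound 1 on the only numbers available, and both are small numbers for the oral dose given.

Compound 3 (`CCCCNc1nc(N)nc2cccc(C(=O)N[C@@H](C)c3ccccc3)c12`) has the same atoms as compound 2, joined differently, with (1-phenylethyl)amino in place of benzyl(methyl)amino on a carbonyl carbon. Among the compounds with values here, no measured pair shows a change of this kind, so its size and direction cannot be read from the data. The expectation therefore rests on compound 2 at 37 ng.h/mL, with no step beyond the scatter expected in this assay. The expected step is a 1.2-fold higher number from compound 2 to compound 3 (0.09 log units; within the scatter), an estimate that stays within the scatter. The estimated value for compound 3 is 45 ng.h/mL, with an expected range of 12 ng.h/mL to 170 ng.h/mL.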

Compound 3, area under the concentration-time curve: 439 ng.h/mL
Compound 3: middle estimate off by 9.8-fold (0.99 log units), on the low side; measured number above the stated range.
By their numbers in this assay, from the lowest: compounds 2 and 1 (each within the scatter of the next); then compound 3.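

In this assay, (1-phenylethyl)amino in place of benzyl(methyl)amino on a carbonyl carbon gives a 12-fold higher number from compound 2 to compound 3 (1.07 log units; beyond the scatter), so the group at this position can change the read-out by a large margin even with the heavy atoms of the group unchanged in number and kind. The earlier compounds shown here gave no sign of this: compound 1 and compound 2 lie within the scatter of each other, while compound 3 stands clear of both at 439 ng.h/mL. The entering group differs from the leaving one in two counted respects, 1 hydrogen-bond donor and 1 defined stereocentre, and this single step cannot separate them.

A plain benzylamino group, or the opposite stereoisomer of compound 3, would bear on which of the two goes with the higher number. Nothing at hand bears on the cause of the step.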